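A few compounds are considered here, and "the series" means these few. Any claim that something is new, unique, unknown or untested is made for them only; others in the source may bear on it.

Measured compounds:
compound 2 `Cc1ccc(S(=O)(=O)NC(=O)Nc2ccccc2C(=O)/C=C/c2cccc([N+](=O)[O-])c2)cc1` — in an ADME assay on the whole organism for cytotoxicity, with Artemia salina as the target, with a stated time of 24 h (on this read-out higher numbers stand for an effect only at larger amounts of compound and lower numbers for an effect already at smaller amounts), compound 2 gives 44.5 ug/mL
compound 1 `Cc1ccc(S(=O)(=O)NC(=O)Nc2ccccc2C(=O)/C=C/c2ccccc2[N+](=O)[O-])cc1` — compound 1 gives 40.1 ug/mL

Compound 2 holds the highest of the two numbers in this assay; its nearest neighbour is compound 1, and the step of a 1.1-fold higher number from compound 1 to compound 2 (0.05 log units; within the scatter) lies within the scatter, so the two are not to be ordered.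

The change to compound 3 `C=CCOc1ccc(/C=C/C(=O)c2ccccc2NC(=O)NS(=O)(=O)c2ccc(C)cc2)cc1` is 4-(allyloxy)phenyl in place of 3-nitrophenyl on a double-bonded chain carbon bound to a double-bonded chain carbon. Going by the values given here, only one measured step is available in this assay, and it does not bear directly on this change: it moves the nitro group to another position on the same ring and leaves the number where it was. Nothing measured speaks to removing the nitrophenyl altogether or to introducing an allyloxy group. Among the compounds with values here, with the single step showing this assay indifferent to the one change tried so far, the expectation for compound 3 is no step beyond the scatter, but with a wide range to cover the untested group. Compound 3 is estimated at 45 ug/mL, within 18 ug/mL to 110 ug/mL. This estimate implies a step of a 1.0-fold higher number from compound 2 to compound 3 (0.00 log units; within the scatter).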

Compound 3, concentration for half-maximal effect: 6.11 ug/mL
Compound 3: middle estimate off by 7.4-fold (0.87 log units), on the high side; the measured number lies below the stated range.
By their numbers in this assay, from the lowest: compound 3; then compounds 1 and 2 (each within the scatter of the next).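

At the place on a double-bonded chain carbon bound to a double-bonded chain carbon, the group does matter in this assay: 4-(allyloxy)phenyl in place of 3-nitrophenyl gives a 7.3-fold lower number from compound 2 to compound 3 (0.86 log units; beyond the scatter), and in place of 2-nitrophenyl it gives a 6.6-fold lower number from compound 1 to compound 3 (0.82 log units; beyond the scatter). The indifference seen earlier therefore holds only for the exchange between the two nitrophenyl groups, and does not extend to the place as a whole, since compound 3 shows its effect at smaller amounts than either compound 1 or compound 2. No measurement at hand accounts for this step.

The change removes the nitro group and brings in the allyloxy group in a single move, so these compounds cannot separate the loss of the one from the gain of the other. A plain phenyl at this place would address the loss of the nitro group alone, while a methoxyphenyl or a propoxyphenyl would show whether the effect depends on the allyl double bond or only on an ether oxygen on the ring.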